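Three Carbamates at the Limit and an Untested Fourth

This account rests on a few compounds, and the source may have more. Where it says the series, first, only, none or still open, it means among the compounds named here.

Compound 1 `C#CCN1CCC(OC(=O)Nc2ccccc2)CC1` was tested in an assay on BTI-TN-5B1-4 cells for inhibition of Amine oxidase [flavin-containing] A (Homo sapiens), read by fluorescence and Amplex Red, using microsomes, with a stated time of 15 min; a higher number here means a weaker inhibitor, a lower number a stronger inhibitor. In this assay compound 1 gives > 100000 nM, which is a limit of the assay rather than a number. Compound 2 `O=C(Nc1ccccc1)OC1CCN(Cc2ccccc2)CC1` carries phenyl in place of ethynyl on a saturated chain carbon bound to an amine nitrogen in a ring. In this assay compound 2 gives > 100000 nM, again a limit. The step that the two limits leave unreadable from compound 1 to compound 2 therefore cannot be sized. Compound 3 `C#CCN1CCCC(OC(=O)Nc2ccc(C(C)C)cc2)C1` rests on a different core from compound 1, and the difference between the two cores is not broken down here. In this assay compound 3 gives > 100000 nM, also a limit. Among the compounds with values here, every value measured so far sits at the limit of > 100000 nM in this assay, at which 3 of the 3 values shown sit. Compound 4 `CC(C)c1ccc(NC(=O)OC2CCCN(Cc3ccccc3)C2)cc1` has not been measured; it differs from compound 3 by phenyl in place of ethynyl on a saturated chain carbon bound to an amine nitrogen in a ring, the same change that separates compound 1 from compound 2. For compound 4 the expected step in this assay is a step that the limit leaves unreadable from compound 3 to compound 4, because the matching step that the two limits leave unreadable from compound 1 to compound 2 left both of its ends at a limit. For compound 4 the expected value in this assay is 150000 nM, within a range from 40000 nM to 600000 nM, and the assay is most likely to report only a limit once more.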

Compound 4, half-maximal inhibitory concentration: > 100000 nM
Compound 4 ended at the assay's limit (the forecaster's own chance of this, stated with the estimate: 85%); the middle value does not contradict the limit.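

In this assay compound 4 gives > 100000 nM, which is a limit of the assay and not a number. Within the data shown here, compound 3 also stands at a limit, so no step from compound 3 to compound 4 can be read. Whether propargyl or benzyl matters at all stays open, because all four compounds rest at one mark: the limit of > 100000 nM in this assay, at which 4 of the 4 values shown sit.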